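Methoxy for methyl on the aryl ester ring

A few compounds are considered here, and "the series" means these few. Any claim that something is new, unique, unknown or untested is made for them only; others in the source may bear on it.

The two measured compounds share a core in which an aryl ester carries a side chain ending in a dimethylamino group. Compound 1 `Cc1ccccc1C(=O)OC(CCN(C)C)c1ccc(Cl)cc1` gives, in an assay on NIH3T3 cells with Urotensin-2 receptor (Homo sapiens) as the target (a lower number here means a smaller maximal response, a higher number a larger maximal response), a largest response of 126%. Compound 2 `Cc1cccc(C(=O)OC(CCN(C)C)c2ccc(Cl)cc2)c1C` gives in this assay a largest response of 91%, the lower of the two numbers, and the step of a number 35 percentage points lower from compound 1 to compound 2 (beyond the scatter) is beyond the scatter.

Compound 3 `COc1cccc(C(=O)OC(CCN(C)C)c2ccc(Cl)cc2)c1C` has not yet been measured. It differs from compound 2 by methoxy in place of methyl on an aromatic carbon. Among the measured compounds shown here, no measured pair shows a methoxy entering in place of a methyl, so no step speaks to this change directly; the only measured step, a number 35 percentage points lower from compound 1 to compound 2 (beyond the scatter), concerns a substituent added to the same ring and shows that a change on that ring can move the largest response by a large amount. For the measured compounds named here, with only that indirect guide, the step of a number 1 percentage points lower from compound 2 to compound 3 (within the scatter) is expected to stay within the scatter, with a wide margin either way. For compound 3 the estimated largest response in this assay is 90%, between 65% and 120%.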

Compound 3, largest response reached (reported as efficacy), in percent of the reference or control that the assay uses: 88%
Compound 3: the middle estimate sits 2 percentage points above what was measured; measured number inside the range.
By their numbers in this assay, from the lowest: compounds 3 and 2 (each within the scatter of the next); then compound 1.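

In this assay, the aromatic carbon ortho to a methyl group and meta to a large group has now carried both methyl and methoxy, and the step of a number 3 percentage points lower from compound 2 to compound 3 (within the scatter) shows that the largest response does not separate these two groups. Adding the oxygen of the methoxy, with its one hydrogen-bond acceptor by count, therefore brings no readable change at this position. Set against hydrogen at the same carbon, methoxy gives the step of a number 38 percentage points lower from compound 1 to compound 3 (beyond the scatter) and so stands with methyl, which gave the step of a number 35 percentage points lower from compound 1 to compound 2 (beyond the scatter), apart from the hydrogen of compound 1. Nothing available here accounts for methyl and methoxy reading alike or for either one differing from hydrogen.

The compounds shown leave open whether a longer chain such as ethoxy, a hydroxyl or an amine at this carbon would stay level with methyl and methoxy or move the largest response. They also leave open whether a halogen such as chlorine there would behave as these two groups do or would read closer to hydrogen.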